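Only One Number Before the Added Methoxy

The source may hold more compounds than are shown below. What is called first, only, known or untested is meant among the compounds shown, and "the series" means these compounds.

Compound 1 (`COc1cc(Nc2n[nH]c(-c3cccnc3Nc3cc(OC)cc(OC)c3)n2)cc(OC)c1`): no result ("not determined" (no result reported))
Compound 2 (`COc1cccc(Nc2n[nH]c(-c3cccnc3Oc3cc(OC)cc(OC)c3)n2)c1`): measured (21 nM)

For the measured compounds named here, in a functional assay on A-431 cells (Homo sapiens) (on this read-out lower numbers stand for an effect already at smaller amounts and higher numbers for an effect only at larger amounts of compound), compound 2 gives the only number (21 nM) and has no measured neighbour to be ranked against. Compound 3 (`COc1cc(Nc2n[nH]c(-c3cccnc3Oc3cc(OC)cc(OC)c3)n2)cc(OC)c1`) carries methoxy in place of hydrogen on an aromatic carbon, turning 3-methoxyphenyl into 3,5-dimethoxyphenyl. Going by the values given here, no measured pair shows what such a change does, so no step beyond the scatter is expected in this assay in either direction. Compound 3 is expected near 20 nM (estimated range 6 nM to 70 nM).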

Compound 3, half-maximal effective concentration: 23 nM
For compound 3 the middle estimate is 1.2-fold (0.06 log units) below the measured one; measured number inside the range.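

In this assay, for the compounds shown here, this is the first measured pair, and it reads a 1.1-fold higher number from compound 2 to compound 3 (0.04 log units; within the scatter), so the two numbers cannot be told apart. At this place on the ring, going from 3-methoxyphenyl to 3,5-dimethoxyphenyl therefore brings no step beyond the scatter. Nothing given here accounts for this result.

From the compounds shown here alone, whether an amine, a carboxylic acid or a longer chain at this place would behave the same stays open. The comparison of compound 3 with compound 1 cannot be read, since compound 1 has no result.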